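The compounds below may be only part of what the source reports. "The series", "measured", "known", "first", "only" and "open" are said of these compounds alone.

Measured compounds:
- compound 1, `N#CCNC(=O)[C@@H]1C[C@@H](S(=O)(=O)c2ccccc2Cl)C[C@H]1C(=O)N1CCOCC1`: 0.5 nM
- compound 2, `CC(C)(C#N)NC(=O)[C@@H]1C[C@@H](S(=O)(=O)c2ccccc2)C[C@H]1C(=O)N1CCOCC1`: 3 nM
- compound 3, `C[C@@H]1CN(C(=O)[C@@H]2C[C@H](S(=O)(=O)c3ccccc3)C[C@H]2C(=O)NC2(C#N)CC2)C[C@H](C)O1`: 0.4 nM

In an assay on isolated protein for inhibition of cathepsin S (Homo sapiens), read by fluorescence, with a stated time of 20 min (on this read-out lower numbers stand for stronger inhibition and higher numbers for weaker inhibition), compound 3 gives the lowest of the three numbers. Compound 1 sits close to it, with the gap within the usual scatter, so no order between the two can be claimed. Compound 2 is the furthest away, with a clearly higher number that lies beyond the scatter.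

Compound 4, `N#CC1(NC(=O)[C@@H]2C[C@@H](S(=O)(=O)c3ccccc3)C[C@H]2C(=O)N2CCC(O)CC2)CC1`, differs from compound 3 by 4-hydroxypiperidin-1-yl in place of 2,6-dimethylmorpholin-4-yl on a carbonyl carbon. Among the compounds with values here, no measured pair shows this change alone, so the expectation rests on the closeness of compound 1 and compound 3 across their amide variations. A small step toward a slightly higher number is expected, a 2.5-fold higher number from compound 3 to compound 4 (0.40 log units; beyond the scatter), most of it within the scatter. Compound 4 is therefore estimated at 1 nM, in a range from 0.3 nM to 4 nM.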

Compound 4, half-maximal inhibitory concentration: 1 nM
The estimate for compound 4 equals the measured number at the digits printed, and the stated range covers the measured number.
By their numbers in this assay, from the lowest: compounds 3, 1 and 4 (each within the scatter of the next, the first and the last beyond it); then compound 2.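

In this assay, within the data shown here, the change from 2,6-dimethylmorpholin-4-yl to 4-hydroxypiperidin-1-yl on a carbonyl carbon gives a 2.5-fold higher number from compound 3 to compound 4 (0.40 log units; beyond the scatter) as the first step that can be read at this position. Compound 4 still reaches 1 nM with a hydrogen-bond donor in this group and no defined stereocentres in it. No available evidence explains the step.

The compounds shown do not separate the effect of the hydroxyl group from that of losing the methyl groups and the ring oxygen. On these data alone, whether a carboxylic acid on the piperidine ring or an open-chain diethylamino group would be tolerated on this carbonyl carbon remains open.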